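The compounds below may be only part of what the source reports. "The series", "measured", "known", "first", "only" and "open" are said of these compounds alone.

Measured so far:
compound 1 `COc1cccc(OC)c1OCCNCCOc1ccccc1OCc1ccccc1` — 9.37
compound 2 `COc1cccc(OC)c1OCCNCCOc1ccccc1OCc1cccc([N+](=O)[O-])c1` — 9.28

Both compounds share the same core and were tested in a functional assay on thoracic aorta for antagonist activity at Alpha-1D adrenergic receptor (Rattus norvegicus); a lower number here means a less potent compound, a higher number a more potent compound, by a factor of ten per unit of this negative logarithm. Compound 1 gives 9.37, and compound 2 gives 9.28. Compound 2 carries the lower of the two numbers, but the step between them is a number 0.09 log units lower from compound 1 to compound 2 (within the scatter), so the two compounds cannot be told apart on potency.

Compound 3 `COc1cccc(COc2ccccc2OCCNCCOc2c(OC)cccc2OC)c1` has not yet been measured. It differs from compound 2 in one place: methoxy in place of nitro on an aromatic carbon.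

Within the data shown here, the only measured step that bears on this position is the one from compound 1 to compound 2, where a nitro group took the place of hydrogen and the number moved by a number 0.09 log units lower from compound 1 to compound 2 (within the scatter). That step shows this position tolerates a change of group without a move beyond the scatter. Among the measured compounds shown here, no measured pair shows a methoxy group at this position, so the expectation rests on that single step alone. For compound 3 a step of about a number 0.02 log units higher from compound 2 to compound 3 (within the scatter) is therefore expected, which is none beyond the scatter. The estimate for compound 3 in this assay is 9.3, with a range from 8.8 to 9.8.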

Compound 3, negative logarithm of the antagonist equilibrium constant: 9.12
Beside the measured number, compound 3's estimate is 0.18 log units above it; measured number inside the range.
By their numbers in this assay, from the lowest: compounds 3, 2 and 1 (each within the scatter of the next).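

In this assay, the exchange of nitro for methoxy comes to a number 0.16 log units lower from compound 2 to compound 3 (within the scatter), and methoxy in place of hydrogen comes to a number 0.25 log units lower from compound 1 to compound 3 (within the scatter). The earlier compounds shown here showed only that this position accepts a nitro group, whereas there are now two different groups on the same aromatic carbon, and hydrogen, nitro and methoxy all leave the number within the scatter of one another. Within these three compounds, then, the 3-substituent on the benzyl group can be changed in atom make-up and in hydrogen-bond acceptor count without a step that stands out from repeat-measurement noise, and no measurement shown here offers an explanation for this result.

Going by these compounds, whether an amine, a carboxylic acid or a longer chain on this aromatic carbon would also stay within the scatter remains open. Each group is also seen at this one place on the ring, and all the numbers come from this assay alone, so other places on the ring and other receptors are still unanswered.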